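The source may report more compounds than this note shows. Statements on the series, on what has been measured and on what is new or still open speak of the compounds shown alone.

Compound 1 `Cc1nc(N)sc1CCCNC(=N)NC(=O)C[C@@H](C)c1ccccc1` gives 53.7 nM in an in vitro functional assay on Sf9 cells for agonist activity at histamine H2 receptor (Homo sapiens), read by GTPgammaS binding (on this read-out lower numbers stand for an effect already at smaller amounts and higher numbers for an effect only at larger amounts of compound), and compound 2 `Cc1nc(N)sc1CCCNC(=N)NC(=O)C[C@H](C)c1ccccc1` gives 28.2 nM in this assay. Of the two numbers compound 2 has the lowest, yet there is only a 1.9-fold lower number from compound 1 to compound 2 (0.28 log units; within the scatter), a step that rests on (the fact that one of compounds 1 and 2 is drawn with a defined configuration and the other without, at the place where they differ). Compound 3 `Cc1nc(N)sc1CCCNC(=N)NC(=O)C[C@@H](C)C1CCCCC1` has not been measured in this assay. It differs from compound 2 by 1-cyclohexylethyl in place of 1-phenylethyl on a saturated chain carbon bound to a carbonyl carbon. Going by the values given here, the one measured step, which is a change of configuration at a saturated chain carbon, does not touch the ring that is exchanged here, so no measured step bears on this change. With a cyclohexyl taking the place of a phenyl on a saturated chain carbon bound to a carbonyl carbon, the number for compound 3 is expected to differ from that of compound 2 by no more than a 1.6-fold higher number from compound 2 to compound 3 (0.20 log units; within the scatter), and compound 3 is estimated at 45 nM with a range from 15 nM to 150 nM.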

Compound 3, half-maximal effective concentration: 20.4 nM
The estimate for compound 3 lay 2.2-fold (0.34 log units) above the measured number; measured number inside the range.
By their numbers in this assay, from the lowest: compounds 3, 2 and 1 (each within the scatter of the next, the first and the last beyond it).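

In this assay, the saturated cyclohexyl ring serves at this position at least as well as the aromatic phenyl ring, so aromaticity in this ring is not required for the effect. Where the configuration drawn at the chain carbon stays the same, the exchange of phenyl for cyclohexyl on a saturated chain carbon bound to two saturated chain carbons gives a step beyond the scatter (a 2.6-fold lower number from compound 1 to compound 3 (0.42 log units; beyond the scatter)), whereas the exchange of 1-phenylethyl for 1-cyclohexylethyl stays within it (a 1.4-fold lower number from compound 2 to compound 3 (0.14 log units; within the scatter)). Nothing at hand explains the effect of this ring exchange.

The compounds shown leave open how the cyclohexyl compound of the opposite configuration would read. They also leave open how a cyclopentyl ring, a piperidine ring or an open hexyl chain would fare in this place.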